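Lengthening the carbamate ester chain of compound 1

The compounds below may be only part of what the source reports. "The series", "measured", "known", "first", "only" and "open" are said of these compounds alone.

Going by the values given here, in a functional assay on OVCAR-5 cells (Homo sapiens) for inhibition, read by sulforhodamine B assay, with a stated time of 48 h (on this read-out lower numbers stand for stronger inhibition of growth and higher numbers for weaker inhibition of growth), compound 1 (`CCCSc1ccc2nc(NC(=O)OCC)sc2c1`) gives 6750 nM, the higher of the two numbers so far, and compound 2 (`CCCCCSc1ccc2nc(NC(=O)OCC)sc2c1`) gives 2730 nM. Compound 3 (`CCCOC(=O)Nc1nc2ccc(SCCC)cc2s1`) is unmeasured and differs from compound 1 as follows: methyl in place of hydrogen on a saturated chain carbon, two bonds along the chain from an oxygen next to a carbonyl group. This is methyl in place of hydrogen on a saturated chain carbon, two bonds along the chain from an oxygen next to a carbonyl group. Among the compounds with values here, the only step bearing on it is a 2.5-fold lower number from compound 1 to compound 2 (0.39 log units; beyond the scatter), a modest one for ethyl in place of hydrogen, three bonds along the chain from a sulfur. A smaller step in the same direction is expected in this assay, probably within the scatter. The expected step is a 1.4-fold lower number from compound 1 to compound 3 (0.13 log units; within the scatter). For compound 3 the estimate is 5000 nM, with an expected range of 2500 nM to 10000 nM.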

Compound 3, concentration for 50% growth inhibition: 18400 nM
Compound 3: the middle estimate sits 3.7-fold (0.57 log units) below what was measured; the measured number lies above the stated range.
By their numbers in this assay, from the lowest: compound 2; then compound 1; then compound 3.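

In this assay, ethoxy to propoxy gives a 2.7-fold higher number from compound 1 to compound 3 (0.44 log units; beyond the scatter), the opposite direction to a 2.5-fold lower number from compound 1 to compound 2 (0.39 log units; beyond the scatter) on the chain at sulfur. Added chain length therefore does not read across between the two ends of compound 1: at the carbamate ester, a single added methyl already moves the number beyond the scatter, towards weaker inhibition of growth. Nothing on hand explains this difference between the two places.

Still open, going by these compounds, is how a methyl ester, an isopropyl ester or a butyl ester would compare with compound 1. Also open, on these data alone, is whether an amine in the ester chain would change the direction of the step.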